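Chloro-tetrazolylbenzylamide series: intrinsic clearance notes

The source may report more compounds than this note shows. Statements on the series, on what has been measured and on what is new or still open speak of the compounds shown alone.

Measured compounds:
- compound 1 `CCCC[C@@H](O)C(=O)N1N=CC[C@H]1C(=O)NCc1cc(Cl)ccc1-n1cnnn1`: < 12 mL.min-1.g-1
- compound 2 `CC(C)(C)C[C@@H](O)C(=O)N1[C@@H]2C[C@@H]2C[C@H]1C(=O)NCc1cc(Cl)ccc1-n1cnnn1`: 71 mL.min-1.g-1
- compound 3 `CC(C)(C)C[C@@H](O)C(=O)N1OCC[C@H]1C(=O)NCc1cc(Cl)ccc1-n1cnnn1`: < 12 mL.min-1.g-1

The read-out is an ADME assay on liver for metabolic stability, with Liver microsome (Homo sapiens) as the target, read by LC-MS, using microsomes; a lower number here means slower removal, a higher number faster removal of the compound. For compound 1 the result of < 12 mL.min-1.g-1 is a limit of the assay, not a number. For compound 3 the result of < 12 mL.min-1.g-1 is likewise a limit. Among the measured compounds shown here, compound 2 gives a number, 71 mL.min-1.g-1, and is the one compound with a measurable figure. Within this small set compound 1 sits with compound 3 at the limit (the limit of < 12 mL.min-1.g-1 in this assay, at which 2 of the 3 values shown sit). For the measured compounds named here, no step between two measured compounds differing in one place is available, so the effect of any single change remains unquantified here.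

The unmeasured compound 4 `O=C(NCc1cc(Cl)ccc1-n1cnnn1)[C@@H]1CC=NN1C(=O)[C@H](O)C1CCCCC1` differs from compound 1 in one place: cyclohexyl in place of butyl on a saturated chain carbon bound to a carbonyl carbon and an oxygen on a saturated carbon. For this step the expectation is a modest rise in clearance, an at least 1.6-fold higher number from compound 1 to compound 4 (0.22 log units; that floor lies within the scatter), possibly still within the scatter. Compound 4 is therefore estimated at 20 mL.min-1.g-1, with a range from 8 mL.min-1.g-1 to 55 mL.min-1.g-1, and a real chance that only a limit is returned again.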

Compound 4, intrinsic clearance in microsomes: 63 mL.min-1.g-1
Estimate against measurement, compound 4: 3.2-fold (0.50 log units) below; the whole stated range lies below it.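

Among the compounds shown here, at the saturated chain carbon bound to a carbonyl carbon and an oxygen on a saturated carbon, cyclohexyl in place of butyl gives the first single change that can be read in this assay, with an at least 5.2-fold higher number from compound 1 to compound 4 (0.72 log units; beyond the scatter). Going by these compounds, compound 1 gives < 12 mL.min-1.g-1, which is a limit of the assay and not a number, so the step is a floor and its true size remains unknown. With compound 4 at a measurable figure, this position can carry a compound away from the limit, and the core of compound 1 does not by itself hold a compound there: the limit of < 12 mL.min-1.g-1 in this assay, at which 2 of the 4 values shown sit.

The compounds shown do not separate the ring from the larger carbon count; a straight hexyl chain or a cyclopentyl ring at this position would bear on that. On these data alone, whether the change acts alike on the cores of compound 2 and compound 3 also remains open.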